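The compounds below may be only part of what the source reports. "The series", "measured", "known", "first", "only" and "open" are said of these compounds alone.

Compound 1 `C/C=C1/[C@H](O[C@@H]2O[C@H](CO)[C@@H](O)[C@H](O)[C@H]2O)OC=C(C(=O)OC)[C@H]1CC(=O)OC[C@H]1O[C@@H](OCc2ccccc2)[C@H](O)[C@@H](O)[C@@H]1O`: 32500 nM
Compound 2 `C/C=C1/[C@H](O[C@@H]2O[C@H](CO)[C@@H](O)[C@H](O)[C@H]2O)OC=C(C(=O)OC)[C@H]1CC(=O)OCCc1ccc(O)c(O)c1`: > 80000 nM

Compound 1 and compound 2 were tested in a functional assay on RAW264.7 cells (Mus musculus) for inhibition, read by Griess assay, with a stated time of 24 h; a higher number here means a weaker inhibitor, a lower number a stronger inhibitor. Within the data shown here, compound 1 gives 32500 nM in this assay, the only plain number among the values shown. For compound 2 the assay reports only a limit, > 80000 nM. This is the limit of > 80000 nM in this assay, at which 1 of the 2 values shown sits. Neither measured compound is a strong inhibitor.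

Compound 3 `C/C=C1/[C@H](O[C@@H]2O[C@H](CO)[C@@H](O)[C@H](O)[C@H]2O)OC=C(C(=O)OC)[C@H]1CC(=O)OC[C@H]1O[C@@H](OCCc2ccc(O)c(O)c2)[C@H](O)[C@@H](O)[C@@H]1O` has not been measured. It differs from compound 1 in one place: 3,4-dihydroxybenzyl in place of phenyl on a saturated chain carbon bound to an oxygen on a saturated carbon. Among the measured compounds shown here, no measured pair of compounds shares this single change, so no measured step guides the expectation directly. The estimated step of a 1.2-fold higher number from compound 1 to compound 3 (0.09 log units; within the scatter) is expected to lie within the scatter or lean toward weaker inhibition, with a real chance that only a limit is returned. Compound 3 is expected to give 40000 nM in this assay, within 15000 nM to 90000 nM.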

Compound 3, half-maximal inhibitory concentration: 48900 nM
Estimate against measurement, compound 3: 1.2-fold (0.09 log units) below; low and high end bracket the measured number.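

In this assay, putting 3,4-dihydroxybenzyl in place of phenyl on a saturated chain carbon bound to an oxygen on a saturated carbon gives a step that stays within the scatter (a 1.5-fold higher number from compound 1 to compound 3 (0.18 log units; within the scatter)). Among these compounds, this is the first measured step at this position, and it shows that the larger group, with its added hydrogen-bond donors and acceptors, leaves the reading essentially unchanged, with a plain number still returned rather than a limit. Nothing shown gives a cause for this result.

The compounds shown leave open whether any group at this place can move the reading beyond the scatter, since only these two aromatic groups are compared there. Going by these compounds, an amine, a carboxylic acid or a plain hydrogen in place of the phenyl remains untested among them.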